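The source may hold more compounds than are shown below. What is called first, only, known or untested is meant among the compounds shown, and "the series" means these compounds.

Measured so far in a functional assay on RCC4 cells (Homo sapiens) for antiproliferative activity, read by XTT assay, with a stated time of 48 h; a lower number here means a stronger inhibitor, a higher number a weaker inhibitor:

- compound 1, `CC(=O)OC[C@H]1O[C@@H](n2cc(CN(c3ccc(C)cc3)S(=O)(=O)c3ccccc3)nn2)[C@H](OC(C)=O)[C@@H]1OC(C)=O`: 230000 nM
- compound 2, `CC(=O)OC[C@H]1O[C@@H](n2cc(CN(c3ccc(Cl)cc3)S(=O)(=O)c3ccccc3)nn2)[C@H](OC(C)=O)[C@@H]1OC(C)=O`: 250000 nM
- compound 3, `CC(=O)OC[C@H]1O[C@@H](n2cc(CN(c3ccc(C)cc3)S(=O)(=O)c3ccccc3)nn2)[C@H](OC(C)=O)[C@@H](OC(C)=O)[C@@H]1OC(C)=O`: 130000 nM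

Compounds 1 and 2 share one sugar-bearing core and differ in a single spot: chloro in place of methyl on an aromatic carbon. That change produced a 1.1-fold higher number from compound 1 to compound 2 (0.04 log units; within the scatter), so in this assay the two compounds are indistinguishable within the usual spread of repeated measurements.

Compound 3 carries a different core. How the core of compound 3 differs from the core of compound 1 is not broken down here; the two differ in more than one place. In this assay compound 3 and compound 1 also fall within the scatter of each other, and so do compound 3 and compound 2, so no order among the three measured compounds can be read from these numbers.

Compound 4, `CC(=O)OC[C@H]1O[C@@H](n2cc(CN(c3ccc(Cl)cc3)S(=O)(=O)c3ccccc3)nn2)[C@H](OC(C)=O)[C@@H](OC(C)=O)[C@@H]1OC(C)=O`, has not yet been measured. It stands to compound 3 exactly as compound 2 stands to compound 1: chloro in place of methyl on an aromatic carbon. The place of the change is described in the same words for both pairs, so it is the same change on a different core. Since the same change between compound 1 and compound 2 gave a 1.1-fold higher number from compound 1 to compound 2 (0.04 log units; within the scatter), the step from compound 3 to compound 4 is expected to be of similar size, a 1.1-fold higher number from compound 3 to compound 4 (0.03 log units; within the scatter), that is, within the scatter. Compound 4 is therefore estimated at 140000 nM in this assay, with a plausible range from 70000 nM to 280000 nM.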

Compound 4, half-maximal inhibitory concentration: 115000 nM
Beside the measured number, compound 4's estimate is 1.2-fold (0.09 log units) above it, within the range that was stated.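

In this assay, the swap of 4-methylphenyl to 4-chlorophenyl gives a 1.1-fold lower number from compound 3 to compound 4 (0.05 log units; within the scatter), so on this second core too the change leaves the number where it was, as far as this kind of measurement can tell. The step therefore carries over from one core to the other without any readable difference, and the two results agree: the same change on two cores in this assay, a 1.1-fold higher number (0.04 log units; within the scatter) from compound 1 to compound 2 and a 1.1-fold lower number (0.05 log units; within the scatter) from compound 3 to compound 4, 1.2-fold (0.09 log units) apart, within the scatter of two such steps. Among the compounds shown here, this shows only that the swap is silent on these two cores in this one cell assay; one step reads as higher and the other as lower, but neither direction means anything when both lie within the scatter, and two pairs cannot show that methyl and chloro would be interchangeable on other cores or in other assays, nor why the numbers stay put.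

The compounds shown leave open what other groups would do at the same place on the aromatic ring, such as an amine, a nitrile or a carboxylic acid, since methyl and chloro are the only two on view there. They also leave open whether a change elsewhere, such as free hydroxyl groups in place of the acetate esters on the sugar, would move the number beyond the scatter.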